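From 2-methoxyphenyl to 4-methoxyphenyl in a growth inhibition series

A few compounds are considered here, and "the series" means these few. Any claim that something is new, unique, unknown or untested is made for them only; others in the source may bear on it.

In a functional assay on PC-3 cells (Homo sapiens) for inhibition, read by sulforhodamine B assay, with a stated time of 48 h, tested at 50 uM (on this read-out higher numbers stand for more inhibition of growth at the one concentration tested and lower numbers for less inhibition of growth), compound 1 (`COc1ccccc1/C=C/C(=O)/C=C/c1ccc(OCc2cn(CCCOc3cc(=O)oc4ccccc34)nn2)c(OC)c1`) is reported as "not active" (no number reported), with no number attached, so it has no exact place on the numerical scale. Two related compounds do have numbers. Compound 2 (`COc1ccc(/C=C/C(=O)/C=C/c2ccc(OCc3cn(CCOc4cc(=O)oc5ccccc45)nn3)c(OC)c2)cc1OC`) gives 19%, and compound 3 (`COc1cc(/C=C/C(=O)/C=C/c2cc(OC)c(OC)c(OC)c2)ccc1OCc1cn(CCCCOc2cc(=O)oc3ccccc23)nn1`) gives 5%. Within the data shown here, neither differs from compound 1 in only one place, so no measured step is available as a direct guide.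

Compound 4 (`COc1ccc(/C=C/C(=O)/C=C/c2ccc(OCc3cn(CCCOc4cc(=O)oc5ccccc45)nn3)c(OC)c2)cc1`) has not yet been measured. The structural change that leads to it is 4-methoxyphenyl in place of 2-methoxyphenyl on a double-bonded chain carbon bound to a double-bonded chain carbon. Here, 4-methoxyphenyl stands in place of 2-methoxyphenyl on a double-bonded chain carbon bound to a double-bonded chain carbon, while the rest of the core of compound 1 is kept.

Without a number for the starting point, only a small upward step in this assay is expected, and a step no larger than the usual scatter would fit this expectation equally well. The expected landing zone is the low range marked by compound 3 at 5% and compound 2 at 19%, although another report without a number remains possible. The estimated value for compound 4 is 12%, with an expected range from 0% to 30%.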

Compound 4, percent growth inhibition at one concentration: "not active" (no number reported)
Compound 4: no number reported; the estimate stays without a comparison.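

In this assay, among these compounds, compound 1 gives "not active" (no number reported) and compound 4 gives "not active" (no number reported) so no step between these two compounds can be read. The compounds shown leave open whether 4-methoxyphenyl in place of 2-methoxyphenyl changes growth inhibition at all. Nothing shown offers an explanation for either report.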